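Swapping the Fluorinated Ring on Compound 1

The compounds below may be only part of what the source reports. "The series", "measured", "known", "first", "only" and "open" are said of these compounds alone.

Of the compounds shown here, three sharing one core have been tested in a functional assay on HCT-116 cells (Homo sapiens) for cytotoxicity, read by MTT assay, with a stated time of 48 h; a lower number here means a stronger inhibitor, a higher number a weaker inhibitor. Compound 1 `CCNC(=O)c1cc(Oc2cccc(NC(=S)Nc3ccc(F)c(F)c3)c2)ccn1` gives 30300 nM in this assay. Compound 2 `O=C(NC1CCCCC1)c1cc(Oc2cccc(NC(=S)Nc3ccc(F)c(F)c3)c2)ccn1` gives 8900 nM, and compound 3 `O=C(c1cc(Oc2cccc(NC(=S)Nc3ccc(F)c(F)c3)c2)ccn1)N1CCCC1` gives 52000 nM. Among these three numbers, compound 1 stands second highest: the step of a 3.4-fold lower number from compound 1 to compound 2 (0.53 log units; beyond the scatter) lies beyond the scatter, while the step of a 1.7-fold higher number from compound 1 to compound 3 (0.23 log units; within the scatter) lies within it. The step of a 5.8-fold higher number from compound 2 to compound 3 (0.77 log units; beyond the scatter) is also beyond the scatter.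

Compound 4 `CCNC(=O)c1cc(Oc2cccc(NC(=S)Nc3cccc(C(F)(F)F)c3)c2)ccn1` has not yet been measured. It differs from compound 1 in one place: 3-(trifluoromethyl)phenyl in place of 3,4-difluorophenyl on an amide-type nitrogen. All three measured steps change the group attached to the carbonyl carbon of the core; none of them touches the ring on the amide-type nitrogen whose other neighbour is the thiocarbonyl carbon. So no measured step bears on the change from compound 1 to compound 4, and the data give no basis for expecting a move in either direction. The expectation is therefore a step no larger than the scatter, a 1.0-fold lower number from compound 1 to compound 4 (0.00 log units; within the scatter), with a wide uncertainty around it. Compound 4 is estimated to give 30000 nM in this assay, within a range from 10000 nM to 90000 nM.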

Compound 4, half-maximal inhibitory concentration: 19400 nM
Beside the measured number, compound 4's estimate is 1.5-fold (0.19 log units) above it; the range from low to high includes it.
By their numbers in this assay, from the lowest: compound 2; then compounds 4, 1 and 3 (each within the scatter of the next, the first and the last beyond it).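

Among these compounds, this is the first look at the ring on the amide-type nitrogen whose other neighbour is the thiocarbonyl carbon, since every earlier step changed only the group on the carbonyl carbon. In this assay, putting 3-(trifluoromethyl)phenyl in place of 3,4-difluorophenyl gives a 1.6-fold lower number from compound 1 to compound 4 (0.19 log units; within the scatter), so this one exchange leaves the two compounds indistinguishable, whereas changing the group on the carbonyl carbon gave a 3.4-fold lower number from compound 1 to compound 2 (0.53 log units; beyond the scatter) and moved the number beyond the scatter. Nothing given here speaks to why this ring exchange came out as it did.

Among the compounds shown here, the only ring exchange shown sits on the ethyl amide of compound 1, so it remains open whether the same exchange would go the same way on the cyclohexyl amide of compound 2 or the pyrrolidine amide of compound 3. Also open, from the compounds shown here alone, is what a plain phenyl ring, a ring carrying a methoxy group, a nitrile or an amine, or a simple alkyl chain would do on this nitrogen, so one exchange cannot yet say how much this position tolerates in general.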